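From Methylphenyl to Methylphenylamino on a Carbonyl

The source may report more compounds than this note shows. Statements on the series, on what has been measured and on what is new or still open speak of the compounds shown alone.

In a functional assay on HUVEC cells (Homo sapiens) for inhibition, with stated times of 2 h and 72 h (a higher number here means a weaker inhibitor, a lower number a stronger inhibitor), compound 1 (`COc1cc2nccc(Oc3ccc4c(NC(=O)c5cccc(C(F)(F)F)c5)nn(C)c4c3)c2cc1OC`) gives 9 nM while compound 2 (`COc1cc2nccc(Oc3ccc4c(NC(=O)c5cccc(C)c5)nn(C)c4c3)c2cc1OC`) gives 2 nM and so holds the lower, stronger number of the two. Compound 3 (`COc1cc2nccc(Oc3ccc4c(NC(=O)Nc5ccc(C)cc5)nn(C)c4c3)c2cc1OC`) differs from compound 2 in one place, with (4-methylphenyl)amino in place of 3-methylphenyl on a carbonyl carbon. Among the compounds with values here, the only measured step is a 4.5-fold lower number from compound 1 to compound 2 (0.65 log units; beyond the scatter) with methyl in place of trifluoromethyl on an aromatic carbon. That modest step concerns a different change, so it offers only a rough guide to size and none to direction. A similarly modest move is expected in this assay and a slightly weaker result is the cautious guess. The estimated change is a 2.5-fold higher number from compound 2 to compound 3 (0.40 log units; beyond the scatter) with real doubt about its sign. Compound 3 is expected near 5 nM with an estimated range from 1 nM to 25 nM in this measurement.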

Compound 3, half-maximal inhibitory concentration: 3 nM
Compound 3: middle estimate off by 1.7-fold (0.22 log units), on the high side; low and high end bracket the measured number.
By their numbers in this assay, from the lowest: compounds 2 and 3 (each within the scatter of the next); then compound 1.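

In this assay, the change on the carbonyl carbon gives a 1.5-fold higher number from compound 2 to compound 3 (0.18 log units; within the scatter) and so shows that this position accepts (4-methylphenyl)amino as well as 3-methylphenyl, with no difference that can be read between them. Set against the trifluoromethyl compound, the same group gives a 3.0-fold lower number from compound 1 to compound 3 (0.48 log units; beyond the scatter) and so joins 3-methylphenyl as a second group that reads better than 3-(trifluoromethyl)phenyl at this place. Nothing available explains why these groups read as they do.

This single change brings in the amino nitrogen with its hydrogen-bond donor and also moves the methyl from the 3-methylphenyl to the 4-methylphenyl arrangement, and the compounds shown do not separate those two parts. Going by these compounds, how the position would respond to a morpholine, a carboxylic acid or a plain butyl chain in place of the aromatic ring also remains open.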